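The source may hold more compounds than are shown below. What is called first, only, known or untested is meant among the compounds shown, and "the series" means these compounds.

Compound 3 `Cc1ccccc1NC(=O)c1cc(C)n(-c2cccc(C(F)(F)F)c2)n1` is the starting point. In an assay on HEK293 cells for binding affinity to Neuropeptide Y receptor type 5 (Homo sapiens), read by radioligand binding (on this read-out higher numbers stand for weaker inhibition and lower numbers for stronger inhibition), compound 3 gives 573 nM. Of the two plain numbers available, that of compound 3 is the smaller, yet the change a 1.4-fold lower number from compound 1 to compound 3 (0.14 log units; within the scatter) is within the scatter, so the two compounds cannot be told apart on this evidence. Compound 1 `Cc1cc(C(=O)Nc2ccc(F)cc2)nn1-c1cccc(C(F)(F)F)c1` gives 800 nM in this assay. Compound 2 `Cc1cc(C(=O)Nc2cc(Cl)cc(Cl)c2)nn1-c1ccccc1C(F)(F)F` shows only a limit, > 1000 nM, and not a number; (the limit of > 1000 nM in this assay, at which 1 of the 3 values shown sits).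

Compound 4 `Cc1cc(C(=O)Nc2cccc(I)c2)nn1-c1cccc(C(F)(F)F)c1` has not yet been measured. The change from compound 3 is 3-iodophenyl in place of 2-methylphenyl on an amide-type nitrogen. Within the data shown here, the only measured step that touches the same place is the swap of one aryl group for another on the amide nitrogen, a 1.4-fold lower number from compound 1 to compound 3 (0.14 log units; within the scatter), which stayed within the scatter. On that basis the step of a 1.0-fold lower number from compound 3 to compound 4 (0.02 log units; within the scatter) is expected to be small, in no particular direction beyond the scatter. Compound 4 is therefore estimated at 550 nM in this assay, with a plausible range of 200 nM to 1500 nM.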

Compound 4, half-maximal inhibitory concentration: 670 nM
Beside the measured number, compound 4's estimate is 1.2-fold (0.09 log units) below it; low and high end bracket the measured number.
By their numbers in this assay, from the lowest: compounds 3, 4 and 1 (each within the scatter of the next). At a limit, above all of these: compound 2.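

Iodine now enters this aryl group on the amide-type nitrogen, and in this assay the number barely moves: a 1.2-fold higher number from compound 3 to compound 4 (0.07 log units; within the scatter). Measured against the other aryl group at this place, the picture is the same: a 1.2-fold lower number from compound 1 to compound 4 (0.08 log units; within the scatter). So 4-fluorophenyl, 2-methylphenyl and 3-iodophenyl cannot be told apart here, even though they carry three different substituents at three different ring positions, which the earlier pair alone could not show.

On these data alone, all three groups are substituted phenyl rings, so it remains open whether a different kind of group at this nitrogen, such as a longer alkyl chain or a phenyl ring bearing an amine or a carboxylic acid, would shift the number beyond the scatter. Nothing available explains why these three groups give such similar numbers.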